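Trifluoromethyl in Place of Cyano: Rat Microsomal Half-life

The compounds below may be only part of what the source reports. "The series", "measured", "known", "first", "only" and "open" are said of these compounds alone.

Measured so far:
compound 1, `COc1ccccc1N1CCN(CCCCNC(=O)c2ccc(-c3ccsc3)cc2)CC1`, gives 0.04 h in an ADME assay on microsomes from liver (Rattus norvegicus) for metabolic stability, read by LC-MS, using NADPH; on this read-out lower numbers stand for a shorter-lived compound and higher numbers for a longer-lived compound
compound 2, `O=C(NCCCCN1CCN(c2ccc(O)cc2)CC1)c1ccc(-c2ccsc2)cc1`, gives 0.19 h in this assay
compound 3, `N#Cc1cccc(N2CCN(CCCCNC(=O)c3ccc(-c4ccsc4)cc3)CC2)c1`, gives > 1 h in this assay

The value of compound 3 is only a limit of the assay, (the limit of > 1 h in this assay, at which 1 of the 3 values shown sits). Compound 3 thus stands at the top of the numbers shown, reached through an at least 25-fold higher number from compound 1 to compound 3 (1.39 log units; beyond the scatter) and through an at least 5.2-fold higher number from compound 2 to compound 3 (0.72 log units; beyond the scatter). Compound 4, `O=C(NCCCCN1CCN(c2cccc(C(F)(F)F)c2)CC1)c1ccc(-c2ccsc2)cc1`, differs from compound 3 by trifluoromethyl in place of cyano on an aromatic carbon. Neither measured step touches the trifluoromethyl, so no direction can be read from them; the step from a limit is itself uncertain. The estimate is an at least 1.2-fold lower number from compound 3 to compound 4 (0.09 log units; that floor lies within the scatter). Compound 4 is expected at 0.8 h, between 0.2 h and 3 h.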

Compound 4, half-life: 0.282 h
Estimate against measurement, compound 4: 2.8-fold (0.45 log units) above; low and high end bracket the measured number.
By their numbers in this assay, from the lowest: compound 1; then compounds 2 and 4 (each within the scatter of the next). At a limit, above all of these: compound 3.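

On this aromatic carbon, the half-life in this assay depends on which group is present: there is an at least 3.5-fold lower number from compound 3 to compound 4 (0.54 log units; beyond the scatter). On these data alone, the true size of this step stays unknown, since the value of compound 3 is a limit of the assay: the limit of > 1 h in this assay, at which 1 of the 4 values shown sits. Trifluoromethyl does not carry the whole gain seen with cyano, giving a 7.1-fold higher number from compound 1 to compound 4 (0.85 log units; beyond the scatter), but only a 1.5-fold higher number from compound 2 to compound 4 (0.17 log units; within the scatter).

As far as these compounds go, whether a chlorine, a methyl or a carboxamide on this carbon would fall nearer compound 3 or compound 4 stays open.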